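The compounds below may be only part of what the source reports. "The series", "measured", "known", "first", "only" and "open" are said of these compounds alone.

Measured compounds:
Compound 1 `CC(=O)n1ncc2c(NC(=O)NCc3cc(C(F)(F)F)nn3-c3cccc(Cl)c3)cccc21` gives 17.4 nM in an assay on CHO-K1 cells for antagonist activity at transient receptor potential cation channel subfamily V member 1 (Homo sapiens), read by FLIPR and calcium flux, with a stated time of 6 min; on this read-out lower numbers stand for stronger inhibition and higher numbers for weaker inhibition.
Compound 2 `O=C(NCc1cc(C(F)(F)F)nn1-c1ccc(Cl)cc1)Nc1cccc2[nH]ncc12` gives 2.5 nM in this assay.

Among these two numbers compound 2 stands lowest; the nearest is compound 1, whose higher number lies beyond the usual scatter of repeated measurements. Compound 3 `O=C(NCc1cc(C(F)(F)F)nn1-c1ccc(F)c(Cl)c1)Nc1cccc2[nH]ncc12` has not yet been measured. It differs from compound 2 in one place: 3-chloro-4-fluorophenyl in place of 4-chlorophenyl on an aromatic nitrogen. Going by the values given here, no measured pair shows this change, so its size cannot be read from the data; everything else in compound 3 is kept as in compound 2. The step that is expected in this assay, a 1.3-fold lower number from compound 2 to compound 3 (0.10 log units; within the scatter), is therefore taken to be small, at most within the scatter, with a slight lean to a lower number. Compound 3 is estimated at 2 nM, with a range from 0.7 nM to 6 nM.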

Compound 3, inhibition constant: 0.6 nM
For compound 3 the middle estimate is 3.3-fold (0.52 log units) above the measured one; measured number outside the range, below it.
By their numbers in this assay, from the lowest: compound 3; then compound 2; then compound 1.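

In this assay, the step to 3-chloro-4-fluorophenyl on the aromatic nitrogen is a 4.2-fold lower number from compound 2 to compound 3 (0.62 log units; beyond the scatter), so the group at this place can change the number beyond the scatter while everything else in the molecule stays the same. The earlier compounds shown here could not show this, as compound 1 and compound 2 differ in more than one place and gave no step at this position. Nothing available explains why this change lowers the number.

The compounds shown leave open how the step divides between the chlorine and the fluorine of the entering group, which arrive together in compound 3. They also leave open how this place would respond to a 4-fluorophenyl or a 4-methoxyphenyl group on the same core.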